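Aryl exchange on the carbonyl carbon in a cytotoxicity series

The source may hold more compounds than are shown below. What is called first, only, known or untested is meant among the compounds shown, and "the series" means these compounds.

Measured so far:
- compound 1 `COc1cc(-c2cc(/C=C/C(=O)c3ccc(N)cc3)[nH]n2)cc(OC)c1OC` gives 94% in a functional assay on PC-3 cells (Homo sapiens) for cytotoxicity, read by sulforhodamine B assay, with a stated time of 48 h, tested at 0.1 uM; a lower number here means a stronger effect, a higher number a weaker effect of the compound at the concentration tested
- compound 2 `COc1ccc(C(=O)/C=C/c2cc(-c3cc(OC)c(OC)c(OC)c3)n[nH]2)cc1` gives 95% in this assay

Compound 2 holds the highest of the two numbers; its nearest neighbour is compound 1, separated by a number 1 percentage points higher from compound 1 to compound 2 (within the scatter). Compound 3 `COc1cc(-c2cc(/C=C/C(=O)c3ccc(F)c(F)c3)[nH]n2)cc(OC)c1OC` differs from compound 2 in one place: 3,4-difluorophenyl in place of 4-methoxyphenyl on a carbonyl carbon. Within the data shown here, the only measured step, a number 1 percentage points higher from compound 1 to compound 2 (within the scatter), concerns methoxy in place of amino on an aromatic carbon, not the group on the carbonyl carbon, so it bears on this change only loosely; it shows that one aromatic substituent exchange stayed within the scatter. No step beyond the scatter is therefore expected, a number 3 percentage points lower from compound 2 to compound 3 (within the scatter). Compound 3 is estimated at 92%, between 78% and 102%.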

Compound 3, a percentage reported as activity, at one concentration (the size of the read-out at that concentration, not a potency): 93%
Beside the measured number, compound 3's estimate is 1 percentage points below it; measured number inside the range.
By their numbers in this assay, from the lowest: compounds 3, 1 and 2 (each within the scatter of the next).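

With 3,4-difluorophenyl on the carbonyl carbon, this assay gives a number 2 percentage points lower from compound 2 to compound 3 (within the scatter) against 4-methoxyphenyl and a number 1 percentage points lower from compound 1 to compound 3 (within the scatter) against 4-aminophenyl. The position now carries three different aryl groups, one of them with no hydrogen-bond acceptor, and this single-concentration read-out does not separate them. No supporting measurement bears on this result. Open, as far as these compounds go, is whether a non-aromatic group on the carbonyl carbon, such as cyclohexyl, or an aryl group bearing a carboxylic acid would leave the number in the same place. Also open, from the compounds shown here alone, is whether higher concentrations would separate these three compounds.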